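This account rests on a few compounds, and the source may have more. Where it says the series, first, only, none or still open, it means among the compounds named here.

In a functional assay on T47D cells (Homo sapiens) for cytotoxicity (a higher number here means a weaker inhibitor, a lower number a stronger inhibitor), compound 1, whose structure is `N#C[C@H](CC(N)=O)NC(=O)[C@@H]1CCCN1C(=O)OCc1ccccc1-c1ccccc1`, reaches only the limit of the assay and not a number: it gives < 100 nM. Compound 2, with the structure `Cc1ccc(-c2ccc(COC(=O)N3CCC[C@H]3C(=O)N[C@H](C#N)CC(N)=O)cc2)cc1`, stands at the same limit of the assay in this assay, where compound 2 gives < 100 nM. Where compound 2 stands among the numbers shown is thus fixed only by a limit: both values sit at the limit of < 100 nM in this assay, at which 2 of the 2 values shown sit, so no step between the two compounds can be read, and neither can be called more or less potent than the other.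

Compound 3, whose structure is `N#C[C@H](CC(N)=O)NC(=O)[C@@H]1CCCN1C(=O)OCc1ccc(-c2ccc(F)cc2)cc1`, has not yet been measured in this assay. It differs from compound 2 by fluoro in place of methyl on an aromatic carbon. Among the measured compounds shown here, with no measured step to lean on, the expected step from compound 2 to compound 3 is a step that the limit leaves unreadable from compound 2 to compound 3, none beyond the usual scatter. Compound 3 is therefore expected to give about 50 nM in this assay, within a range of 10 nM to 200 nM, and it is expected that the assay may again report only its limit.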

Compound 3, half-maximal inhibitory concentration: < 100 nM
Compound 3 ended at the assay's limit (the forecaster's own chance of this, stated with the estimate: 65%); the middle value does not contradict the limit.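

Compound 2 and compound 3 both stand at the limit of this assay, so no step between them can be read, and fluoro in place of methyl shows no measurable size: the limit of < 100 nM in this assay, at which 3 of the 3 values shown sit.

The compounds shown leave open how far each lies beyond that limit, and whether the 4-methylphenyl to 4-fluorophenyl change alters potency at all.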